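A carbamate on the amine of compound 1

A few compounds are considered here, and "the series" means these few. Any claim that something is new, unique, unknown or untested is made for them only; others in the source may bear on it.

Compound 1 `Cc1nc2c(OCc3ccccc3)cccn2c1N` has the higher number of the two measured compounds: in a functional assay on the whole organism with Rattus norvegicus as the target, at a dose of 40 mg/kg by the intraperitoneal route (on this read-out higher numbers stand for more inhibition at the one dose given (going by the name of the read-out) and lower numbers for less inhibition), compound 1 gives 99%. Among the measured compounds shown here, its only measured neighbour is compound 2 `Cc1ccn2c(N)c(C)nc2c1OCc1ccccc1`, which in this assay gives 60%; the step of a number 39 percentage points lower from compound 1 to compound 2 (beyond the scatter), a methyl in place of hydrogen on an aromatic carbon, shows that a single change on the shared core can cost a great deal on this read-out.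

Compound 3 `COC(=O)Nc1c(C)nc2c(OCc3ccccc3)cccn12` differs from compound 1 in another place: methoxycarbonyl in place of hydrogen on a nitrogen on an aromatic ring, which read one bond further out turns amino into (methoxycarbonyl)amino. For the measured compounds named here, no measured step touches this nitrogen, so the only guidance is that compound 1 sits at the top of the range and that the one measured step, a number 39 percentage points lower from compound 1 to compound 2 (beyond the scatter), was large and downward. The change to compound 3 is therefore expected to lower the number rather than raise it, with wide uncertainty. Compound 3 is estimated at 70% in this assay, between 25% and 99%, an expected step of a number 29 percentage points lower from compound 1 to compound 3 (beyond the scatter).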

Compound 3, a percentage reported as inhibition, in the whole organism at one dose (the size of the read-out at that dose, not a potency): 0%
Compound 3: the middle estimate sits 70 percentage points above what was measured; measured number below the stated range.
By their numbers in this assay, from the lowest: compound 3; then compound 2; then compound 1.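

Among the compounds shown here, this result is the first measured change at the amino nitrogen of compound 1, and it shows that this position matters at least as much to the read-out as the aromatic carbon changed in compound 2. Where the methyl step, a number 39 percentage points lower from compound 1 to compound 2 (beyond the scatter), still left clear inhibition at the one dose given, the change of amino to (methoxycarbonyl)amino, a number 99 percentage points lower from compound 1 to compound 3 (beyond the scatter), leaves none at all in this assay. For this one change, then, the free amino group of compound 1 cannot be exchanged for the carbamate without losing the whole of the effect at this dose. Nothing shown here bears on why this change has so large an effect.

The compounds shown leave open whether the loss belongs to the methoxycarbonyl group alone or to any substituent on this nitrogen, since a single methyl, an acetyl or a longer carbamate such as ethoxycarbonyl would each test a different part of that question. They also leave open whether a higher dose would restore any inhibition for compound 3, and whether the same carbamate would cost as much on the core of compound 2.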